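This account rests on a few compounds, and the source may have more. Where it says the series, first, only, none or still open, it means among the compounds named here.

Compound 1 `CCCC(=O)N1CCC(NS(=O)(=O)c2ccc(NC(=O)c3ccccc3)c3ccccc23)CC1` is the starting point. In an in vitro functional assay on CHO/Galpha16 cells for antagonist activity at C-C chemokine receptor type 8 (Homo sapiens), read by FLIPR (on this read-out lower numbers stand for stronger inhibition and higher numbers for weaker inhibition), compound 1 gives 12.5 nM. Among the three measured compounds its number is the second highest. Compound 3 `CCCC(=O)N1CCC(NS(=O)(=O)c2ccc(NC(=O)c3ccc(CC)cc3)c3ccccc23)CC1` gives 10.8 nM, and the step of a 1.2-fold lower number from compound 1 to compound 3 (0.06 log units; within the scatter) stays within the scatter. Compound 2 `CCCC(=O)N1CCC(NS(=O)(=O)c2ccc(NC(=O)C(CC)CC)c3ccccc23)CC1` gives 639 nM, and the step of a 51-fold higher number from compound 1 to compound 2 (1.71 log units; beyond the scatter) is a large one; the step of a 59-fold lower number from compound 2 to compound 3 (1.77 log units; beyond the scatter) is large as well.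

Compound 4 `CCCC(=O)N1CCC(NS(=O)(=O)c2ccc(NC(=O)c3ccc(C(C)(C)C)cc3)c3ccccc23)CC1` differs from compound 1 in a single place: tert-butyl in place of hydrogen on an aromatic carbon. Among the measured compounds shown here, the measured step that bears most directly on this change is the one to compound 3, where ethyl in place of hydrogen on the same aromatic carbon gave a 1.2-fold lower number from compound 1 to compound 3 (0.06 log units; within the scatter). The large steps involving compound 2 concern pentan-3-yl in place of phenyl on a carbonyl carbon, a change that removes the ring; compound 4 keeps the ring and only carries tert-butyl on it. A step no larger than the scatter is therefore expected in this assay, with no clear direction. Compound 4 is expected to give about 12 nM, within a range from 5 nM to 30 nM. This amounts to an expected step of a 1.0-fold lower number from compound 1 to compound 4 (0.02 log units; within the scatter).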

Compound 4, half-maximal inhibitory concentration: 6.9 nM
Compound 4: middle estimate off by 1.7-fold (0.24 log units), on the high side; low and high end bracket the measured number.
By their numbers in this assay, from the lowest: compounds 4, 3 and 1 (each within the scatter of the next); then compound 2.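

The new compound shows that this aromatic carbon, already open to ethyl in compound 3, also takes the larger tert-butyl with its 4 carbons: in this assay the result is a 1.8-fold lower number from compound 1 to compound 4 (0.26 log units; within the scatter). Exchanging ethyl for tert-butyl at the same carbon gives a 1.6-fold lower number from compound 3 to compound 4 (0.19 log units; within the scatter), so compounds 1, 3 and 4 cannot be told apart in this assay, and hydrogen, ethyl and tert-butyl at this carbon cannot be ranked. The importance of the ring on the carbonyl carbon also holds with tert-butyl attached, since the comparison with the ring-free pentan-3-yl compound gives a 93-fold lower number from compound 2 to compound 4 (1.97 log units; beyond the scatter), a large step like those already seen for compounds 1 and 3.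

No supporting measurement is available to explain why these three groups read alike or why losing the ring matters so much. The compounds shown also leave open how this same aromatic carbon would respond to a group unlike the hydrocarbon ones tested so far, such as an amine or a carboxylic acid, or to a longer chain such as n-hexyl.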